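Ester-to-acid step on the alkynyloxy coumarin series

The source may report more compounds than this note shows. Statements on the series, on what has been measured and on what is new or still open speak of the compounds shown alone.

Measured compounds in an assay on cells for inhibition of Amine oxidase [flavin-containing] A (Homo sapiens), read by Amplex Red, with stated times of 30 min and 45 min; a higher number here means a weaker inhibitor, a lower number a stronger inhibitor:
compound 1 `C#CCOc1ccc2cc(C(=O)OC)c(=O)oc2c1`: 1570 nM
compound 2 `C#CCCCOc1ccc2cc(C(=O)OC)c(=O)oc2c1`: 953 nM

Compound 2 holds the lowest of the two numbers in this assay; the step of a 1.6-fold lower number from compound 1 to compound 2 (0.22 log units; within the scatter) is within the scatter, so compound 1 and compound 2 are not separated.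

Compound 3 `C#CCCCOc1ccc2cc(C(=O)O)c(=O)oc2c1` differs from compound 2 by hydrogen in place of methyl on an oxygen next to a carbonyl group. For the measured compounds named here, the only measured step, a 1.6-fold lower number from compound 1 to compound 2 (0.22 log units; within the scatter), alters the chain on the ether oxygen and leaves the ester untouched, so no measured step bears on the change at the ester. The direction and size of the step from compound 2 to compound 3 are therefore unanchored by the data, and the estimate is deliberately broad. Compound 3 is expected to give about 4000 nM, with a range of 1000 nM to 20000 nM, which means an expected step of a 4.2-fold higher number from compound 2 to compound 3 (0.62 log units; beyond the scatter).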

Compound 3, half-maximal inhibitory concentration: > 10000 nM
Compound 3 gave a limit, no number; the forecaster's own chance of this, stated with the estimate: 25%; at least 2.5-fold (0.39 log units) between middle value and limit.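

Hydrogen in place of methyl on an oxygen next to a carbonyl group, read as methoxycarbonyl to carboxy, gives in this assay an at least 10-fold higher number from compound 2 to compound 3 (1.02 log units; beyond the scatter). The ester is thus the first place in the series where a single change moves the result beyond the scatter, whereas a 1.6-fold lower number from compound 1 to compound 2 (0.22 log units; within the scatter) at the ether chain leaves its two compounds unseparated. Compound 3 gives a limit of the assay and not a number, so the step has a lower bound but no measured size: the limit of > 10000 nM in this assay, at which 1 of the 3 values shown sits.

The compounds shown leave open whether a primary amide or an ethyl ester in this place would stay with compound 2 or with compound 3. Also open, going by these compounds, is whether methoxycarbonyl to carboxy has a step of similar size on the ether chain of compound 1.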